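The compounds below may be only part of what the source reports. "The series", "measured", "known", "first", "only" and "open" are said of these compounds alone.

Working notes on the series: the shared core carries a methanesulfonamide-bearing aryl propanamide linked to a substituted benzylic amine, and the variation sits on the ring that bears the tert-butyl group. In an assay on cells for antagonist activity at transient receptor potential cation channel subfamily V member 1 (Homo sapiens), read by FLIPR and calcium flux, with a stated time of 6 min (on this read-out higher numbers stand for weaker inhibition and lower numbers for stronger inhibition), compound 1 `CC(C(=O)NCc1ccc(C(C)(C)C)nc1N1CCCCCC1)c1ccc(NS(C)(=O)=O)c(F)c1` gives 0.9 nM and compound 3 `CCCCN(C)c1cc(C(C)(C)C)ccc1CNC(=O)C(C)c1ccc(NS(C)(=O)=O)c(F)c1` gives 1 nM, a pair of numbers that lie within the scatter of each other, so no order between them can be read. Going by the values given here, compound 2 `CCOCCOc1nc(C(C)(C)C)ccc1CNC(=O)C(C)c1ccc(NS(C)(=O)=O)c(F)c1` gives 23.9 nM in this assay, and the only single-point step available is a 27-fold higher number from compound 1 to compound 2 (1.42 log units; beyond the scatter), where the ring amine gives way to an ether chain. Compound 3 thus stands with compound 1 at the strong end of the three, far from compound 2.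

Compound 4 `CC1CCN(c2cc(C(C)(C)C)ccc2CNC(=O)C(C)c2ccc(NS(C)(=O)=O)c(F)c2)CC1` is not yet measured. The change from compound 3 is 4-methylpiperidin-1-yl in place of butyl(methyl)amino on an aromatic carbon. The measured step of a 27-fold higher number from compound 1 to compound 2 (1.42 log units; beyond the scatter) bears on it only indirectly: it shows that removing a nitrogen-linked group from this carbon costs a great deal, whereas compound 4 keeps a nitrogen-linked ring much as compound 1 does, and the values of compound 1 and compound 3 show open-chain and cyclic amines giving the same kind of number. No step beyond the scatter is therefore expected, a 1.2-fold higher number from compound 3 to compound 4 (0.08 log units; within the scatter). Compound 4 is estimated at 1.2 nM in this assay, within a range from 0.4 nM to 4 nM.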

Compound 4, inhibition constant: 0.7 nM
Compound 4: the middle estimate sits 1.7-fold (0.23 log units) above what was measured, within the range that was stated.
By their numbers in this assay, from the lowest: compounds 4, 1 and 3 (each within the scatter of the next); then compound 2.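

Working notes, continued: on the ring of carbon only, at the aromatic carbon ortho to a large group and meta to a tert-butyl group, 4-methylpiperidin-1-yl in place of butyl(methyl)amino gives a 1.4-fold lower number from compound 3 to compound 4 (0.15 log units; within the scatter) in this assay, so no order can be read between the ring and the open-chain amine. Going by these compounds alone, this is the first comparison of a cyclic and an open-chain amine that differ in one place only, whereas compound 1 and compound 3 differ in more than one, so here the two kinds of amine can be set side by side on the same core. No measurement on hand says why the two groups give numbers that cannot be told apart.

The compounds shown leave open how a ring with a second hetero atom, such as morpholin-4-yl, or a much shorter amine, such as dimethylamino, would read at this carbon. They also leave open whether 2-ethoxyethoxy at this carbon on the ring of carbon only would give a number as far from those of the amines as compound 2 does in its own series.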